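This account rests on a few compounds, and the source may have more. Where it says the series, first, only, none or still open, it means among the compounds named here.

Compound 1, whose structure is `CC[C@H]1OC(=O)[C@H](C)[C@@H](O[C@H]2C[C@@](C)(OC)[C@@H](OCCCNC(=O)C3CCC3)[C@H](C)O2)[C@H](C)[C@@H](O[C@@H]2O[C@H](C)C[C@H](N(C)C)[C@H]2O)[C@](C)(O)C[C@@H](C)CN(C)[C@H](C)[C@@H](O)[C@]1(C)O`, carries a cyclobutylcarbonyl amide on a side chain and gives 2.62 in a physicochemical assay for lipophilicity, read by HPLC, measured as chromatographic lipophilicity, at pH 7.4; a lower number here means a more polar compound, a higher number a more lipophilic compound. Compound 2, with the structure `CCCCCCCC(=O)NCCCO[C@H]1[C@H](C)O[C@@H](O[C@H]2[C@H](C)[C@@H](O[C@@H]3O[C@H](C)C[C@H](N(C)C)[C@H]3O)[C@](C)(O)C[C@@H](C)CN(C)[C@H](C)[C@@H](O)[C@](C)(O)[C@@H](CC)OC(=O)[C@@H]2C)C[C@@]1(C)OC`, differs from compound 1 only by the change (heptyl in place of cyclobutyl on a carbonyl carbon), and in this assay compound 2 gives 4.1. The step of a number 1.48 log units higher from compound 1 to compound 2 (beyond the scatter) is therefore large and well beyond the scatter of the measurement.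

Compound 3, with the structure `CC[C@H]1OC(=O)[C@H](C)[C@@H](O[C@H]2C[C@@](C)(OC)[C@@H](O)[C@H](C)O2)[C@H](C)[C@@H](O[C@@H]2O[C@H](C)C[C@H](N(C)C)[C@H]2O)[C@](C)(O)C[C@@H](C)CN(C)[C@H](C)[C@@H](OCCCNC(=O)C2CCC2)[C@]1(C)O`, has the same atoms as compound 1 joined differently; the difference between the two cores is not broken down here. In this assay compound 3 gives 3.5, which stands between the values of compound 1 and compound 2.

Compound 4, whose structure is `CCCCCCCC(=O)NCCCO[C@@H]1[C@@H](C)N(C)C[C@H](C)C[C@@](C)(O)[C@H](O[C@@H]2O[C@H](C)C[C@H](N(C)C)[C@H]2O)[C@@H](C)[C@H](O[C@H]2C[C@@](C)(OC)[C@@H](O)[C@H](C)O2)[C@@H](C)C(=O)O[C@H](CC)[C@@]1(C)O`, has not yet been measured. It differs from compound 3 by the change (heptyl in place of cyclobutyl on a carbonyl carbon), which is the same change as that from compound 1 to compound 2, made at the same place, on a carbonyl carbon whose other neighbour is an amide-type nitrogen. Because this change produced the step of a number 1.48 log units higher from compound 1 to compound 2 (beyond the scatter) on the core of compound 1, a step of about the same size is expected on the core of compound 3, namely a number 1.40 log units higher from compound 3 to compound 4 (beyond the scatter). On that basis compound 4 is estimated to give 4.9 in this assay, most likely between 4.4 and 5.4.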

Compound 4, distribution coefficient: 5.18
Estimate against measurement, compound 4: 0.28 log units below; the range from low to high includes it.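

In this assay the change of cyclobutyl to heptyl on a carbonyl carbon gives a number 1.68 log units higher from compound 3 to compound 4 (beyond the scatter) on the core of compound 3, and the same change gives a number 1.48 log units higher from compound 1 to compound 2 (beyond the scatter) on the core of compound 1, so both steps run in the same direction, both are large and both lie beyond the scatter. This shows that, for this one pair of groups at this one place, the step seen on the core of compound 1 carried over to the core of compound 3, with neither core going against it; it does not show that the step would carry over to any further core, or that another pair of groups would behave in the same way. Nothing available here explains the size of the step on either core.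

The compounds shown leave open whether a longer chain than heptyl would extend the step on both cores, or whether the step would keep pace from one core to the other with a shorter chain. They also leave open what an amine or a carboxylic acid at the end of the heptyl chain would do to the readings on these two cores.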